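The compounds below may be only part of what the source reports. "The series", "measured", "known", "first", "only" and "open" are said of these compounds alone.

Compound 1 `O=c1cc(I)n([C@@H]2O[C@H](CO)[C@@H](O)[C@H]2O)c(=O)[nH]1` was run in a functional assay on OCI-Ly7 cells (Homo sapiens) for antiproliferative activity, read by WST assay, with a stated time of 3 days (on this read-out lower numbers stand for stronger inhibition and higher numbers for weaker inhibition), where compound 1 gives only a limit of > 50000 nM and no number. Compound 2 `COC(=O)c1cc(=O)[nH]c(=O)n1[C@@H]1O[C@H](CO)[C@@H](O)[C@H]1O` also reaches only a limit of > 50000 nM in this assay. Compound 3 `O=c1[nH]c(=O)n([C@@H]2O[C@H](CO)[C@@H](O)[C@H]2O)c(I)c1F` likewise stops at a limit of > 50000 nM. The change from compound 1 to compound 2, methoxycarbonyl in place of iodo on an aromatic carbon, shows a step that the two limits leave unreadable from compound 1 to compound 2, and the change from compound 1 to compound 3, fluoro in place of hydrogen on an aromatic carbon, shows a step that the two limits leave unreadable from compound 1 to compound 3. Both rest on (the limit of > 50000 nM in this assay, at which 3 of the 3 values shown sit), so neither has a readable size, and compound 1 cannot be placed more closely than at that limit.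

Compound 4 `CC(=O)OC[C@H]1O[C@@H](n2c(I)cc(=O)[nH]c2=O)[C@H](O)[C@@H]1O` has not yet been measured. It differs from compound 1 by acetyl in place of hydrogen on an oxygen on a saturated carbon, that is, hydroxy to acetoxy, hydroxymethyl to acetoxymethyl. For the measured compounds named here, no measured step touches this oxygen; the two measured steps alter the aromatic ring and are unreadable in size. Nothing among the shown compounds points to a change beyond the scatter in either direction, and the most likely outcome is that compound 4 also returns only a limit. The expected step from compound 1 to compound 4 is a number no higher from compound 1 to compound 4 (the limit leaves the size open). Compound 4 is expected to give 50000 nM in this assay, between 15000 nM and 50000 nM.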

Compound 4, half-maximal inhibitory concentration: 36200 nM
The estimate for compound 4 lay 1.4-fold (0.14 log units) above the measured number, and the stated range covers the measured number.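

Acetyl in place of hydrogen on an oxygen on a saturated carbon, hydroxymethyl to acetoxymethyl, gives the only number among the compounds shown: in this assay compound 4 gives 36200 nM. For the compounds shown here, this is the one readable change on this oxygen, and it shows an at least 1.3-fold lower number from compound 1 to compound 4 (0.14 log units; that floor lies within the scatter), so the acetyl group is tolerated here, but the data do not establish a real gain over compound 1. The size of the step has a floor and no ceiling, and the result places compound 4 within measurable range in this assay while the shared core with a free hydroxymethyl group stays unresolved.

Going by these compounds, the steps that alter the aromatic ring cannot be read, and the same holds for any comparison resting on the limit alone: the limit of > 50000 nM in this assay, at which 3 of the 4 values shown sit. Whether a longer acyl chain such as butyryl, a benzoyl group or an amine-bearing ester on this oxygen would carry the number further down stays open, as does whether acetyl on the remaining hydroxy groups would do the same.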